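Adding a Methoxy to the 4-Fluorophenyl Amide

The compounds below may be only part of what the source reports. "The series", "measured", "known", "first", "only" and "open" are said of these compounds alone.

Three amides built on a shared core have been measured in an assay on isolated protein for binding affinity to melanin-concentrating hormone receptor 1 (Homo sapiens); on this read-out higher numbers stand for weaker inhibition and lower numbers for stronger inhibition. Compound 1 `O=C(NC1CCN(Cc2ccc3ccccc3c2)CC1)c1ccccc1` gives 347 nM. Compound 2 `COc1cc(OC)cc(C(=O)NC2CCN(Cc3ccc4ccccc4c3)CC2)c1` gives 27 nM, and compound 3 `O=C(NC1CCN(Cc2ccc3ccccc3c2)CC1)c1ccc(F)cc1` gives 36 nM. The two substituted amides thus sit close together (a 1.3-fold higher number from compound 2 to compound 3 (0.12 log units; within the scatter)), and the fluoro amide stands well apart from the unsubstituted one (a 9.6-fold lower number from compound 1 to compound 3 (0.98 log units; beyond the scatter)). Compound 4 `COc1cc(C(=O)NC2CCN(Cc3ccc4ccccc4c3)CC2)ccc1F` differs from compound 3 by methoxy in place of hydrogen on an aromatic carbon. Among the measured compounds shown here, no measured step adds a single methoxy, but a 13-fold lower number from compound 1 to compound 2 (1.11 log units; beyond the scatter) shows that two methoxy groups on the phenyl lower the number strongly, while a 1.3-fold higher number from compound 2 to compound 3 (0.12 log units; within the scatter) places the two substituted amides close together. Compound 4 is therefore expected to change little, a 1.4-fold lower number from compound 3 to compound 4 (0.16 log units; within the scatter), and is estimated at 25 nM, within 8 nM to 80 nM.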

Compound 4, inhibition constant: 13 nM
Compound 4: middle estimate off by 1.9-fold (0.28 log units), on the high side; the range from low to high includes it.
By their numbers in this assay, from the lowest: compound 4; then compounds 2 and 3 (each within the scatter of the next); then compound 1.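

In this assay, methoxy placed ortho to the fluoro group adds a step beyond the scatter to what the fluoro group alone gave (a 2.8-fold lower number from compound 3 to compound 4 (0.44 log units; beyond the scatter)). The 4-fluoro-3-methoxyphenyl amide also separates from the 3,5-dimethoxyphenyl amide, which the 4-fluorophenyl amide did not (a 2.1-fold lower number from compound 2 to compound 4 (0.32 log units; beyond the scatter)), and the whole change from the plain phenyl amide is large (a 27-fold lower number from compound 1 to compound 4 (1.43 log units; beyond the scatter)). No measurement offered here accounts for this gain.

Going by these compounds, whether methoxy would give a similar step without the fluoro group remains open. So does whether an ethoxy or hydroxyl group on the same carbon would match it.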